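Swapping the Hydroxy-Methoxy Aryl Group for a Bromophenyl

A few compounds are considered here, and "the series" means these few. Any claim that something is new, unique, unknown or untested is made for them only; others in the source may bear on it.

Measured so far in a functional assay on PC-3 cells (Homo sapiens) for cytotoxicity, read by sulforhodamine B assay, with a stated time of 48 h; on this read-out lower numbers stand for stronger inhibition and higher numbers for weaker inhibition:
Compound 1 `CC(=O)N1N=C(c2cccc3ccccc23)CC1c1ccccc1` gives 8460 nM.
Compound 2 `COc1cc(C2CC(c3cccc4ccccc34)=NN2C(C)=O)ccc1O` gives 2130 nM.

Going by the values given here, compound 2 holds the lower of the two numbers in this assay; its only neighbour is compound 1, and the single step between them, a 4.0-fold lower number from compound 1 to compound 2 (0.60 log units; beyond the scatter), lies beyond the scatter. Compound 3 `CC(=O)N1N=C(c2cccc3ccccc23)CC1c1cccc(Br)c1` has not been measured. It differs from compound 2 in one place: 3-bromophenyl in place of 4-hydroxy-3-methoxyphenyl on a saturated ring carbon. Among the compounds with values here, the one measured step that bears on this position is a 4.0-fold lower number from compound 1 to compound 2 (0.60 log units; beyond the scatter), which shows that putting the hydroxy and methoxy groups onto the plain phenyl lowered the number by a modest amount. Within the data shown here, compound 3 takes both of those groups away again and brings in a bromine instead; no measured compound shows what a bromine does at this position, so that part of the change is a blank. The number for compound 3 is therefore expected to move back toward that of compound 1, with the estimated step of a 2.8-fold higher number from compound 2 to compound 3 (0.45 log units; beyond the scatter). Compound 3 is estimated at 6000 nM, within a range from 2000 nM to 18000 nM.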

Compound 3, half-maximal inhibitory concentration: 12000 nM
Beside the measured number, compound 3's estimate is 2.0-fold (0.30 log units) below it; the measured number falls inside the stated range.
By their numbers in this assay, from the lowest: compound 2; then compounds 1 and 3 (each within the scatter of the next).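

The step of a 1.4-fold higher number from compound 1 to compound 3 (0.15 log units; within the scatter) in this assay shows that adding a bromine to the plain phenyl ring does not set compound 3 apart from compound 1. This gives the first measured view of a substituent on this ring other than the hydroxy and methoxy pair. The larger step of a 5.6-fold higher number from compound 2 to compound 3 (0.75 log units; beyond the scatter) then shows that the lower number of compound 2 is lost when 3-bromophenyl replaces 4-hydroxy-3-methoxyphenyl, so among these three compounds only the hydroxy-and-methoxy-bearing ring stands apart, and this bromine does not stand in for it. No measurement at hand explains why these rings differ in this way.

The compounds shown leave open whether the hydroxy group, the methoxy group or the two together account for the lower number of compound 2, as the two appear only as a pair. They also leave open what a single hydroxy or methoxy group, an amine or a carboxylic acid on this ring would do to the number.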